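Series notes: removing one methoxy from compound 1

This account rests on a few compounds, and the source may have more. Where it says the series, first, only, none or still open, it means among the compounds named here.

Compound 1 `COc1ccc(OC)c(C2CC(c3cc(OC)c(OC)c(OC)c3)=NN2C(C)=O)c1` is read in a functional assay on B16 cells (Mus musculus) for cytotoxicity, read by MTT assay, with a stated time of 72 h; on this read-out higher numbers stand for weaker inhibition and lower numbers for stronger inhibition. In this assay compound 1 gives only a limit, > 100000 nM, not a number. Compound 1 therefore sits at the limit of > 100000 nM in this assay, at which 1 of the 2 values shown sits. Compound 2 `COc1ccc(OC)c(C2=NN(C(C)=O)C(c3ccc(OC)c(OC)c3)C2)c1`, the other measured member, gives 62000 nM in this assay. Compound 3 `COc1ccccc1C1CC(c2cc(OC)c(OC)c(OC)c2)=NN1C(C)=O` differs from compound 1 by hydrogen in place of methoxy on an aromatic carbon. For the measured compounds named here, no step between measured compounds is available, so the change is uncalibrated. With compound 1 at the limit, the step of a number no higher from compound 1 to compound 3 (the limit leaves the size open) is expected to be small, most likely none beyond the scatter. Compound 3 is estimated at 100000 nM, ranging from 30000 nM to 400000 nM, with a fair chance that this assay again reports only a limit.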

Compound 3, half-maximal inhibitory concentration: > 100000 nM
Compound 3 was reported as a limit; the forecaster's own chance of this, stated with the estimate: 55%; the middle value sits exactly at the limit.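

Compound 1 and compound 3 both stand only as limits in this assay, so no step can be read between them. The compounds shown leave open whether going from 2,5-dimethoxyphenyl to 2-methoxyphenyl changes the read-out at all.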